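A few compounds are considered here, and "the series" means these few. Any claim that something is new, unique, unknown or untested is made for them only; others in the source may bear on it.

In a functional assay on B16-F10 cells (Mus musculus) for antiproliferative activity, read by MTT assay, with a stated time of 48 h (a lower number here means a stronger inhibitor, a higher number a weaker inhibitor), compound 1 `COc1ccc(/C=C/c2cc(OC)cc(OC)c2/C=C/C(=O)c2ccc(C(F)(F)F)cc2)cc1` gives 4.3 ug/mL and compound 2 `COc1ccc(/C=C/c2cc(OC)cc(OC)c2/C=C/C(=O)c2ccc(F)cc2)cc1` gives 5.3 ug/mL, while compound 3 `CCOc1ccc(C(=O)/C=C/c2c(/C=C/c3ccc(OC)cc3)cc(OC)cc2OC)cc1` gives 6.4 ug/mL and so stands within the usual scatter of both others. Compound 4 `COc1ccc(/C=C/c2cc(OC)cc(OC)c2/C=C/C(=O)c2ccccc2)cc1` differs from compound 3 by hydrogen in place of ethoxy on an aromatic carbon at the carbon where the three measured compounds differ. The swaps there were small: a 1.5-fold higher number from compound 1 to compound 3 (0.17 log units; within the scatter) and a 1.2-fold higher number from compound 2 to compound 3 (0.08 log units; within the scatter) and also a 1.2-fold higher number from compound 1 to compound 2 (0.09 log units; within the scatter) all lie inside the scatter. Hydrogen itself is untested at that carbon, so some doubt remains. No step beyond the scatter is expected in this assay, so the estimated change is only a 1.2-fold lower number from compound 3 to compound 4 (0.07 log units; within the scatter) and its direction is not secure. The estimate for compound 4 is 5.5 ug/mL with 3.2 ug/mL to 9.5 ug/mL as its expected range.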

Compound 4, half-maximal inhibitory concentration: 3.7 ug/mL
The estimate for compound 4 lay 1.5-fold (0.17 log units) above the measured number; the range from low to high includes it.
By their numbers in this assay, from the lowest: compounds 4, 1, 2 and 3 (each within the scatter of the next).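

Hydrogen at this aromatic carbon, with no substituent at all, can now be compared with all three earlier groups in this assay: ethoxy (a 1.7-fold lower number from compound 3 to compound 4 (0.24 log units; within the scatter)), fluoro (a 1.4-fold lower number from compound 2 to compound 4 (0.16 log units; within the scatter)) and trifluoromethyl (a 1.2-fold lower number from compound 1 to compound 4 (0.07 log units; within the scatter)). None of these steps leaves the scatter, so this assay does not separate the bare phenyl from the three substituted rings. No measurement is available that would help interpret these small steps.
On these data alone, whether an amine, a carboxylic acid or a longer chain at this carbon would give a step beyond the scatter remains open. The compounds shown also say nothing about changes elsewhere on the shared core.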